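Working notes: the step from compound 3 to compound 4

The source may hold more compounds than are shown below. What is called first, only, known or untested is meant among the compounds shown, and "the series" means these compounds.

Measured in a functional assay on HeLa cells (Homo sapiens) for inhibition, read by MTT assay, with a stated time of 72 h; on this read-out lower numbers stand for stronger inhibition and higher numbers for weaker inhibition:
- compound 1 `COc1cccc(/C=C/C(=O)Nc2cc(OC)c(OC)c(OC)c2)c1`: 16500 nM
- compound 2 `C=C(Br)C(=O)Nc1cccc(/C=C/C(=O)Nc2cccc(F)c2)c1`: 1200 nM
- compound 3 `C=C(Br)C(=O)Nc1cccc(/C=C/C(=O)Nc2ccc(F)c(F)c2)c1`: 1900 nM

Compound 3 at 1900 nM lies within the scatter of compound 2 at 1200 nM. Both numbers are well under that of compound 1 at 16500 nM.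

The next compound is compound 4 `C=C(Br)C(=O)Nc1cccc(/C=C/C(=O)NCc2ccc(C)cc2)c1`, with 4-methylbenzyl in place of 3,4-difluorophenyl on an amide-type nitrogen.

Among the compounds with values here, only one measured step bears on this change: a 1.6-fold higher number from compound 2 to compound 3 (0.20 log units; within the scatter). It is a fluoro in place of hydrogen on an aromatic carbon, in the group that now leaves, and it stays within the scatter. Within the data shown here, no measured compound carries a benzyl group on that nitrogen, so the direction is poorly supported.

A small move towards a higher number is expected in this assay, with the estimated step being a 1.3-fold higher number from compound 3 to compound 4 (0.12 log units; within the scatter). The estimate for compound 4 is 2500 nM, with an expected range of 800 nM to 8000 nM.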

Compound 4, half-maximal inhibitory concentration: 1700 nM
Compound 4: middle estimate off by 1.5-fold (0.17 log units), on the high side, and the stated range covers the measured number.
By their numbers in this assay, from the lowest: compounds 2, 4 and 3 (each within the scatter of the next); then compound 1.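

In this assay, 4-methylbenzyl on the amide-type nitrogen gives a 1.1-fold lower number from compound 3 to compound 4 (0.05 log units; within the scatter) and a 1.4-fold higher number from compound 2 to compound 4 (0.15 log units; within the scatter), so neither step leaves the scatter. In these compounds, then, neither fluoro substitution nor a ring attached directly to that nitrogen is needed to keep the number at this level. No measurement here addresses what lies behind this result.

The change to compound 4 alters the ring substituents and the attachment to the nitrogen in a single step, so the two cannot be separated; a 4-methylphenyl group on that nitrogen would be needed to tell them apart. Also open, going by these compounds, is how this position responds to an amine or a carboxylic acid on the ring, or to a longer chain between the nitrogen and the ring.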